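The source may report more compounds than this note shows. Statements on the series, on what has been measured and on what is new or still open speak of the compounds shown alone.

Working notes on the series.

Four compounds share a small set of cores. Compound 1 `Cc1ccc(N2CCN/C2=N\N)cc1` and compound 3 `N/N=C1\NCCN1c1cccc(Cl)c1` both carry an open hydrazone on the ring, while compound 2 `Cc1cccc(N2CCn3c2n[nH]c(=O)c3=O)c1C` is the fused, oxidised variant. In an ADME assay on Vero cells (Chlorocebus sabaeus) for cytotoxicity, with a stated time of 72 h, tested at 10 ug/mL (a higher number here means a stronger effect of the compound at the concentration tested, a lower number a weaker effect), compound 1 gives 0% and compound 2 gives 18%. In this assay compound 3 gives 0%, level with compound 1 at the digits shown, the two together the lowest of the three numbers; compound 2 sits higher than compound 3, and that gap lies beyond the scatter.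

Compound 4 `N/N=C1\NCCN1c1ccccc1` remains to be measured in this assay. It differs from compound 3 in one place: hydrogen in place of chloro on an aromatic carbon. For the measured compounds named here, no step between two measured compounds is known for this assay, so the size of the change on removing the chloro rests only on where compound 3 stands. Given compound 3 at 0%, the step from compound 3 to compound 4 is expected to be small, about a number 2 percentage points higher from compound 3 to compound 4 (within the scatter), in no direction beyond the scatter. Compound 4 is therefore estimated at 2%, within 0% to 12%.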

Compound 4, a percentage reported as inhibition, at one concentration (the size of the read-out at that concentration, not a potency): 0%
Compound 4: the middle estimate sits 2 percentage points above what was measured; the measured number falls inside the stated range.
By their numbers in this assay, from the lowest: compounds 1, 3 and 4 (each within the scatter of the next); then compound 2.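

In this assay the series now has its first measured steps: hydrogen in place of chloro gives no change at the digits printed from compound 3 to compound 4 (within the scatter) and hydrogen in place of methyl gives no change at the digits printed from compound 1 to compound 4 (within the scatter) on the same shared core. Chloro, at its place meta to a group of 7 heavy atoms, and methyl can therefore each give way to hydrogen with no change at the digits printed, and compound 4, which carries neither group, stands level with compound 1 and compound 3. No measurement available bears on why these numbers coincide.

Still open, going by these compounds, is whether an amine, a carboxylic acid or a longer chain on that aromatic carbon would move the read-out beyond the scatter. The read-out comes from one concentration, so it gives no potency for any of these compounds.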